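The source may report more compounds than this note shows. Statements on the series, on what has been measured and on what is new or still open speak of the compounds shown alone.

Compound 1 `COC(=O)c1ccc(-c2cnc(C(=O)CCCCCCc3ccccc3)o2)cc1` gives 40 nM in an assay (Rattus norvegicus) for inhibition of Fatty-acid amide hydrolase 1 (Homo sapiens); a lower number here means a stronger inhibitor, a higher number a weaker inhibitor. Compound 2 `NS(=O)(=O)c1ccc(-c2cnc(C(=O)CCCCCCc3ccccc3)o2)cc1` gives 10 nM, and compound 3 `N#Cc1ccc(-c2cnc(C(=O)CCCCCCc3ccccc3)o2)cc1` gives 40 nM. The step of a 4.0-fold lower number from compound 1 to compound 2 (0.60 log units; beyond the scatter) is a modest gain, whereas no change at the digits printed from compound 1 to compound 3 (within the scatter) leaves the number unchanged, and a 4.0-fold higher number from compound 2 to compound 3 (0.60 log units; beyond the scatter) is a modest loss. Compound 3 therefore sits level with compound 1 at the digits given, the two together at the high end of the three numbers, with compound 2 furthest from it.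

Compound 4 `O=C(CCCCCCc1ccccc1)c1ncc(I)o1` differs from compound 3 by iodo in place of 4-cyanophenyl on an aromatic carbon. Within the data shown here, none of the measured steps bears directly on this change: each of them swaps one group on the aromatic ring for another, while here the whole 4-cyanophenyl is removed and a single iodine takes its place on the five-membered ring. Since the three measured swaps altered the number by at most a modest amount, a loss is expected when the ring is lost, and compound 4 is estimated at 200 nM, within 60 nM to 700 nM, a step of a 5.0-fold higher number from compound 3 to compound 4 (0.70 log units; beyond the scatter).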

Compound 4, inhibition constant: 3 nM
For compound 4 the middle estimate is 67-fold (1.82 log units) above the measured one, and the stated range ends above it.
By their numbers in this assay, from the lowest: compound 4; then compound 2; then compounds 1 and 3 (each within the scatter of the next).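

In this assay, replacing 4-cyanophenyl with iodo gives a 13-fold lower number from compound 3 to compound 4 (1.12 log units; beyond the scatter), so the six-membered aromatic ring on this carbon, next to the ring oxygen, is not required for a low number among these compounds. The earlier compounds shown here changed only the group carried on that ring, so they could not show that removing the whole 4-cyanophenyl would give a large gain rather than a loss. No evidence is at hand that bears on this gain.

The compounds shown leave open whether the gain comes from the iodine itself or from the loss of the 4-cyanophenyl, a question that a bare hydrogen, a bromine or a methyl on this carbon would help to settle. They also leave open how a small amine or a carboxylic acid at this place would compare.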